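The source may hold more compounds than are shown below. What is called first, only, known or untested is meant among the compounds shown, and "the series" means these compounds.

Of the compounds shown here, two that share one core have been measured. Compound 1 `COc1ccc(/C=C/C(=O)c2ccccc2NC(=O)NS(=O)(=O)c2ccc(C)cc2)cc1` gives 28.1 ug/mL in an ADME assay on the whole organism for cytotoxicity, with Artemia salina as the target, with a stated time of 24 h (a lower number here means that less compound is needed, a higher number that more compound is needed for the effect), and compound 2 `Cc1ccc(S(=O)(=O)NC(=O)Nc2ccccc2C(=O)/C=C/c2ccc(O)cc2)cc1` gives 24.3 ug/mL. The step of a 1.2-fold lower number from compound 1 to compound 2 (0.06 log units; within the scatter), so the two numbers sit within the scatter of each other and neither can be called apart. Compound 3 `Cc1ccc(S(=O)(=O)NC(=O)Nc2ccccc2C(=O)/C=C/c2cccc(Br)c2)cc1` differs from compound 2 by 3-bromophenyl in place of 4-hydroxyphenyl on a double-bonded chain carbon bound to a double-bonded chain carbon. Among the compounds with values here, the only measured step, hydrogen in place of methyl on an oxygen on an aromatic ring, stayed within the scatter and gives little guidance on this larger swap. The step of a 1.1-fold lower number from compound 2 to compound 3 (0.04 log units; within the scatter) is therefore expected to be small. Compound 3 is estimated at 22 ug/mL, between 9 ug/mL and 55 ug/mL.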

Compound 3, concentration for half-maximal effect: 4.02 ug/mL
Estimate against measurement, compound 3: 5.5-fold (0.74 log units) above, and the stated range ends above it.
By their numbers in this assay, from the lowest: compound 3; then compounds 2 and 1 (each within the scatter of the next).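

The group on the double-bonded chain carbon clearly matters in this assay, whereas capping the oxygen of compounds 1 and 2 with methyl did not: 3-bromophenyl in place of 4-hydroxyphenyl gives a 6.0-fold lower number from compound 2 to compound 3 (0.78 log units; beyond the scatter), and 3-bromophenyl in place of 4-methoxyphenyl gives a 7.0-fold lower number from compound 1 to compound 3 (0.84 log units; beyond the scatter). The two steps agree, so this result does not depend on which of the two oxygen-bearing rings is replaced. No measurement here explains the change. The swap alters both the ring's substituent and where it sits, and the compounds shown cannot separate these two changes. Going by these compounds, whether 4-bromophenyl, or a ring carrying an amine or a carboxylic acid, would give a number close to that of compound 3 remains open.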